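This account rests on a few compounds, and the source may have more. Where it says the series, first, only, none or still open, it means among the compounds named here.

Measured compounds:
- compound 1 `O=C(c1ncco1)[C@H]1COc2cc(OCc3ccccc3)ccc2C1`: 20 nM
- compound 2 `O=C(c1ncc(-c2ccccn2)o1)[C@H]1COc2cc(OCc3ccccc3)ccc2C1`: 18 nM

Compound 1 has the higher of the two numbers in an assay for inhibition of Fatty-acid amide hydrolase 1 (Rattus norvegicus), using a Dixon plot (on this read-out higher numbers stand for weaker inhibition and lower numbers for stronger inhibition), but the gap to compound 2 is small: the step of a 1.1-fold lower number from compound 1 to compound 2 (0.05 log units; within the scatter) lies within the scatter, so the two values cannot be told apart. Compound 3 `O=C(c1ncco1)[C@@H]1COc2cc(OCc3ccccc3)ccc2C1` has not yet been measured in this assay. It differs from compound 1 in one place: the two compounds have the same atoms and bonds and differ only in configuration as drawn: 1 of 1 stereo elements differ; a stereocentre at a saturated ring carbon is drawn R in compound 1 and S in compound 3. For the measured compounds named here, no measured step bears on such a change; the only step known, from compound 1 to compound 2, adds a ring rather than altering configuration, so it says nothing about what a mirrored stereocentre does here. With nothing to anchor it, the estimate for compound 3 rests on the bare fact that only the drawn configuration changes, and a weaker number is expected, a 10-fold higher number from compound 1 to compound 3 (1.00 log units; beyond the scatter), with wide uncertainty. The estimate for compound 3 in this assay is 200 nM, within a range from 20 nM to 2000 nM.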

Compound 3, inhibition constant: 16 nM
Estimate against measurement, compound 3: 13-fold (1.10 log units) above, outside the stated range (below it).
By their numbers in this assay, from the lowest: compounds 3, 2 and 1 (each within the scatter of the next).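

In this assay, redrawing the stereocentre at the saturated ring carbon from R to S gives a 1.3-fold lower number from compound 1 to compound 3 (0.10 log units; within the scatter), so the two drawn forms cannot be told apart on this read-out. The earlier step changed only an aromatic carbon and said nothing about this stereocentre; now this position has been tested directly, and for this pair its configuration produces no readable difference. The comparison is a clean one, with a single change to consider: the fact that compounds 1 and 3 differ only in the configuration as drawn

From the compounds shown here alone, it remains open whether the same holds once the shared core carries another group, such as the pyridin-2-yl that enters in a 1.1-fold lower number from compound 1 to compound 2 (0.05 log units; within the scatter), on the S form. The compounds shown also leave open whether an amine or a carboxylic acid on that aromatic carbon would make the configuration at this stereocentre matter.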